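A Chloro Group Added to Compound 2

This account rests on a few compounds, and the source may have more. Where it says the series, first, only, none or still open, it means among the compounds named here.

Compound 1 (`CN1CC(=O)N/C1=N\C(=O)Nc1csc(Cl)c1`) and compound 2 (`CN1CC(=O)N/C1=N\C(=O)Nc1ccccn1`) share a core but carry different aromatic rings. In an in vitro ADME assay on microsomes from liver (Rattus norvegicus) for metabolic stability (a higher number here means faster removal of the compound, a lower number slower removal), compound 1 gives 27 mL.min-1.g-1 and compound 2 gives 22 mL.min-1.g-1 as its number. These two values lie within the scatter of each other, so compound 2 stands level with compound 1.

Compound 3 (`CN1CC(=O)N/C1=N\C(=O)Nc1ncccc1Cl`) makes one change to compound 2 (chloro in place of hydrogen on an aromatic carbon): chloro in place of hydrogen on an aromatic carbon, two atoms from the ring nitrogen. Within the data shown here, no measured pair of compounds shows this change, so the forecast is loose. A small rise in this assay is expected, perhaps none beyond the scatter. The estimated step (a 1.3-fold higher number from compound 2 to compound 3 (0.10 log units; within the scatter)) stays modest. For compound 3 the estimate is 28 mL.min-1.g-1 (expected range 13 mL.min-1.g-1 to 55 mL.min-1.g-1).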

Compound 3, intrinsic clearance in microsomes: 53 mL.min-1.g-1
Compound 3: the middle estimate sits 1.9-fold (0.28 log units) below what was measured, within the range that was stated.
By their numbers in this assay, from the lowest: compounds 2, 1 and 3 (each within the scatter of the next, the first and the last beyond it).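

In this assay, chloro in place of hydrogen on an aromatic carbon, two atoms from the ring nitrogen, gives a 2.4-fold higher number from compound 2 to compound 3 (0.38 log units; beyond the scatter). Among these compounds, this is the first single change that can be read directly, and it shows that this position is not silent: one added chlorine atom, with the rest of the structure the same, moves the number beyond the scatter, towards faster removal. Nothing measured here says why the number rises.

On these data alone, whether this rise belongs to chloro alone or would also come with another group at this carbon stays open; a fluoro, methyl or methoxy group there would help to tell. Also open, as far as these compounds go, is whether chloro on the other carbons of this ring would give a step of similar size.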